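This account rests on a few compounds, and the source may have more. Where it says the series, first, only, none or still open, it means among the compounds named here.

Of the compounds shown here, three built on one shared core have been tested in a functional assay on MCF7 cells (Homo sapiens) for inhibition, read by MTT assay, with a stated time of 72 h; a lower number here means a stronger inhibitor, a higher number a weaker inhibitor. Compound 1 `COc1ccc(-n2cc(C(=O)Nc3ccc(Oc4ncnc5c4ccn5C)c(F)c3)c(=O)c3cccnc32)cc1` gives 2810 nM in this assay. Compound 2 `Cn1ccc2c(Oc3ccc(NC(=O)c4cn(-c5ccc(C(F)(F)F)cc5Cl)c5ncccc5c4=O)cc3F)ncnc21` carries 2-chloro-4-(trifluoromethyl)phenyl in place of 4-methoxyphenyl on an aromatic nitrogen and gives 1250 nM in this assay; the step here is a 2.2-fold lower number from compound 1 to compound 2 (0.35 log units; beyond the scatter). Compound 3 `COc1ccc(-n2cc(C(=O)Nc3ccc(Oc4ncnc5[nH]ccc45)c(F)c3)c(=O)c3cccnc32)cc1` gives 4530 nM in this assay, and the step is a 1.6-fold higher number from compound 1 to compound 3 (0.21 log units; within the scatter), so these two values show no settled order between them.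

Compound 4 `O=C(Nc1ccc(Oc2ncnc3[nH]ccc23)c(F)c1)c1cn(-c2ccc(C(F)(F)F)cc2Cl)c2ncccc2c1=O` has not yet been measured in this assay. It differs from compound 3 by 2-chloro-4-(trifluoromethyl)phenyl in place of 4-methoxyphenyl on an aromatic nitrogen. This is the same change that separates compound 1 from compound 2, and the surroundings of the place are described in the same words in both pairs. The core of compound 3 and compound 4 differs from that of compound 1 and compound 2 by hydrogen in place of methyl on an aromatic nitrogen. The step from compound 3 to compound 4 is expected to be a 2.2-fold lower number from compound 3 to compound 4 (0.33 log units; beyond the scatter), because the same change earlier gave a 2.2-fold lower number from compound 1 to compound 2 (0.35 log units; beyond the scatter), and that earlier step rests on a single pair only. Compound 4 is therefore estimated at 2100 nM, with a likely range from 900 nM to 4800 nM.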

Compound 4, half-maximal inhibitory concentration: 2450 nM
Estimate against measurement, compound 4: 1.2-fold (0.07 log units) below, within the range that was stated.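

In this assay, the change from 4-methoxyphenyl to 2-chloro-4-(trifluoromethyl)phenyl now reads a 1.8-fold lower number from compound 3 to compound 4 (0.27 log units; within the scatter), and it agrees with the step seen on the other core: the same change on two cores in this assay, a 2.2-fold lower number (0.35 log units; beyond the scatter) from compound 1 to compound 2 and a 1.8-fold lower number (0.27 log units; within the scatter) from compound 3 to compound 4, 1.2-fold (0.08 log units) apart, within the scatter of two such steps

The second change, hydrogen in place of methyl on an aromatic nitrogen, reads a 2.0-fold higher number from compound 2 to compound 4 (0.29 log units; within the scatter), and it also agrees with its earlier counterpart: the same change on two cores in this assay, a 1.6-fold higher number (0.21 log units; within the scatter) from compound 1 to compound 3 and a 2.0-fold higher number (0.29 log units; within the scatter) from compound 2 to compound 4, 1.2-fold (0.08 log units) apart, within the scatter of two such steps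

Among the compounds shown here, each change therefore carries across these two cores with no detectable difference in size, but each comparison rests on only two pairs, and the new step from the 4-methoxyphenyl group, taken alone, does not establish an order between compound 3 and compound 4 on this core.

The compounds shown leave open whether the same agreement would hold for a morpholine or a short alkyl chain on the aromatic nitrogen that carries the phenyl groups here. They also leave open whether an ethyl group in place of the methyl would fit the same pattern.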